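Butyl amine in place of the ester amide on compound 3

The source may report more compounds than this note shows. Statements on the series, on what has been measured and on what is new or still open speak of the compounds shown alone.

Compound 1, `CCCCCCCCCCCCCCC(NC(=O)OC(C)(C)C)C(=O)O`: 5.1%
Compound 2, `CCCCCCCCCCCCCCC(COCc1ccccc1)NC(=O)CCCC(=O)OC`: 2.5%
Compound 3, `CCCCCCCCCCCCCCC(CO)NC(=O)CCCC(=O)OC`: 18.9%

In an ADME assay on cells (Splenocyte, Mus musculus, strain BALB/c) for cytotoxicity, read by MTT assay, tested at 10 ug/mL (on this read-out lower numbers stand for a weaker effect and higher numbers for a stronger effect at the one concentration tested), compound 3 gives 18.9% and stands highest of the three numbers. The nearest of the others is compound 1, which gives 5.1% in this assay, a gap beyond the scatter. The furthest is compound 2 with 2.5% in this assay. For the measured compounds named here, the single measured step, a number 16.4 percentage points higher from compound 2 to compound 3 (beyond the scatter), is a modest one and lies beyond the scatter.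

Compound 4, `CCCCCCCCCCCCCCC(CO)NCCCC`, has not been measured in this assay. It differs from compound 3 in one place: butyl in place of (3-(methoxycarbonyl)propyl)carbonyl on an amine nitrogen. Going by the values given here, no measured step touches the amine nitrogen, so none bears directly on this change; the one step known concerns an oxygen on a saturated carbon, and compound 1 carries a different group on its nitrogen altogether. Among the compounds with values here, with no direct precedent, the expected step of a number 6.1 percentage points higher from compound 3 to compound 4 (within the scatter) is set close to none beyond the scatter, with a wide range. Compound 4 is therefore estimated at 25% in this assay, between 5% and 55%.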

Compound 4, a percentage reported as activity, at one concentration (the size of the read-out at that concentration, not a potency): 16.4%
The estimate for compound 4 lay 8.6 percentage points above the measured number; the measured number falls inside the stated range.
By their numbers in this assay, from the lowest: compounds 2 and 1 (each within the scatter of the next); then compounds 4 and 3 (each within the scatter of the next).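

For the compounds shown here, the first change at the amine nitrogen leaves the read-out in this assay essentially unmoved: butyl in place of (3-(methoxycarbonyl)propyl)carbonyl gives a number 2.5 percentage points lower from compound 3 to compound 4 (within the scatter). The earlier step concerned only an oxygen on a saturated carbon, whereas this one shows that a group of nine heavy atoms with two double bonds and three hydrogen-bond acceptors can give way to a plain four-carbon chain with no difference that can be told from the scatter. No measurement shown here explains why the two groups read alike.

As far as these compounds go, whether an octyl chain or an acetyl group on this nitrogen would also read alike stays open, as does the result for the unsubstituted primary amine. A single pair also cannot show which part of the departing group, the amide carbonyl or the methyl ester, could be changed alone without a shift.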